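The source may report more compounds than this note shows. Statements on the series, on what has been measured and on what is new or still open speak of the compounds shown alone.

Compound 1 `CN(C)C(=O)c1cc2cnc(Nc3ccc(NC(=O)C4(C(=O)Nc5cccc(F)c5)CC4)cc3)nc2n1C1CCCC1` gives 107%
Compound 2 `CN(C)C(=O)c1cc2cnc(Nc3ccc(NC(=O)C4(C(=O)Nc5ccccc5F)CC4)cc3)nc2n1C1CCCC1` gives 103%

In a functional assay on SiHa cells (Homo sapiens) for inhibition, read by CCK-8 assay, with a stated time of 72 h, tested at 10 uM (a higher number here means more inhibition of growth at the concentration tested, a lower number less inhibition of growth), compound 2 gives 103% and cannot be told apart from compound 1 within the usual scatter. Compound 3 `CN(C)C(=O)c1cc2cnc(Nc3ccc(NC(=O)C4(C(=O)Nc5cccc(Cl)c5)CC4)cc3)nc2n1C1CCCC1` differs from compound 2 by one change 3-chlorophenyl in place of 2-fluorophenyl on an amide-type nitrogen that puts 3-chlorophenyl in place of 2-fluorophenyl on an amide-type nitrogen. Among the measured compounds shown here, the only measured step that bears on this is a number 4 percentage points lower from compound 1 to compound 2 (within the scatter) and it is small. For the measured compounds named here, no measured compound carries 3-chlorophenyl, so this evidence is indirect, and no step beyond the scatter is expected. The expected change is a number 1 percentage points lower from compound 2 to compound 3 (within the scatter) in this assay and lies within the scatter. Compound 3 is estimated at 102% with an expected range from 90% to 112% in this measurement.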

Compound 3, percent growth inhibition at one concentration: 97.3%
For compound 3 the middle estimate is 4.7 percentage points above the measured one; measured number inside the range.
By their numbers in this assay, from the lowest: compounds 3, 2 and 1 (each within the scatter of the next).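

Chloro in place of fluoro on an aromatic carbon gives a number 9.7 percentage points lower from compound 1 to compound 3 (within the scatter) in this assay, and 3-chlorophenyl in place of 2-fluorophenyl gives a number 5.7 percentage points lower from compound 2 to compound 3 (within the scatter). On this amide-type nitrogen, therefore, the 3-chlorophenyl group cannot be told apart from either fluorophenyl group in this measurement. Nothing on hand explains this result.

Going by these compounds, all three compounds carry a halogen on this phenyl ring, so it remains open how a plain phenyl, a methoxy-bearing phenyl or an amine-bearing phenyl would compare.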